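The source may hold more compounds than are shown below. What is called first, only, known or untested is meant among the compounds shown, and "the series" means these compounds.

The measured compounds in a functional assay on EC9706 cells (Homo sapiens) for cytotoxicity, read by MTT assay, with a stated time of 72 h; on this read-out lower numbers stand for stronger inhibition and higher numbers for weaker inhibition:

Compound 1 `Cc1ccc(Cn2cc(CSC(=S)N3CCN(C(=O)NC(C)C)CC3)nn2)cc1` gives > 128000 nM.
Compound 2 `CCN(C)C(=O)N1CCN(C(=S)SCc2cn(Cc3ccc(C)cc3)nn2)CC1` gives 70600 nM.
Compound 3 `COc1ccc(Cn2cc(CSC(=S)N3CCN(C(=O)NC(C)C)CC3)nn2)cc1` gives > 128000 nM.

For compound 1 the value is a limit of the assay, not a number. For compound 3 the value is likewise a limit and not a number. Only compound 2 gives a measured number in this assay.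

Compound 2 differs from compound 1 by ethyl(methyl)amino in place of isopropylamino on a carbonyl carbon. That change produced an at least 1.8-fold lower number from compound 1 to compound 2 (0.25 log units; that floor lies within the scatter). Compound 3 differs from compound 1 by methoxy in place of methyl on an aromatic carbon; the two cores of this study differ only in this way. The step that the two limits leave unreadable from compound 1 to compound 3 cannot be read because the limit of > 128000 nM in this assay, at which 2 of the 3 values shown sit, caps both values.

Compound 4 `CCN(C)C(=O)N1CCN(C(=S)SCc2cn(Cc3ccc(OC)cc3)nn2)CC1` has not yet been measured in this assay. It stands to compound 3 as compound 2 stands to compound 1: the change is ethyl(methyl)amino in place of isopropylamino on a carbonyl carbon, the same change at the same place as before, made on the core that carries methoxy rather than methyl. The step from compound 3 to compound 4 is expected to be an at least 1.5-fold lower number from compound 3 to compound 4 (0.17 log units; that floor lies within the scatter). Going by these compounds, this expectation rests on an at least 1.8-fold lower number from compound 1 to compound 2 (0.25 log units; that floor lies within the scatter), whose floor lies within scatter, and on the fact that compound 3 starts from a limit, so the true starting point is unknown. Compound 4 is therefore estimated at 85000 nM, with a likely range from 35000 nM to 200000 nM, and a fair chance that the assay again reports only a limit.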

Compound 4, half-maximal inhibitory concentration: > 128000 nM
Compound 4 ended at the assay's limit (the forecaster's own chance of this, stated with the estimate: 35%); at least 1.5-fold (0.17 log units) between middle value and limit.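

In this assay compound 4 gives > 128000 nM, which is a limit of the assay and not a number. Among these compounds, whether ethyl(methyl)amino in place of isopropylamino does the same on the methoxy core as on the methyl core cannot be judged, and neither the step from compound 3 to compound 4 nor the step from compound 1 to compound 3 can be read, because both ends of each step sit at the same cap: the limit of > 128000 nM in this assay, at which 3 of the 4 values shown sit. The one new step that can be read is an at least 1.8-fold higher number from compound 2 to compound 4 (0.25 log units; that floor lies within the scatter), for methoxy in place of methyl on an aromatic carbon, so these results show neither that the change carries over to the second core nor that it fails there.

The compounds shown leave open how other groups would read in this assay, such as a carboxylic acid or an amine in place of the methyl or methoxy on that aromatic carbon, or a longer chain such as dibutylamino on the carbonyl carbon. Among the compounds shown here, compound 2 is the only compound here with a measured number, so any such group would for now have a single real value to be compared with.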